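The source may hold more compounds than are shown below. What is called first, only, known or untested is meant among the compounds shown, and "the series" means these compounds.

Compound 2 `Cc1ccccc1C1C(C#N)=C(N)OC(c2c[nH]c3ccccc23)=C1C#N` gives, in a functional assay, tested at 200 ug/mL (a lower number here means a weaker effect, a higher number a stronger effect of the compound at the concentration tested), a read-out of 21.4%. Within the data shown here, compound 1 `N#CC1=C(N)OC(c2c[nH]c3ccccc23)=C(C#N)C1c1ccc2ccccc2c1` appears in this assay only as "not active" (no number reported), so compound 2 stands as the single entry with a number. Compound 3 `Cc1ccc(C2C(C#N)=C(N)OC(c3c[nH]c4ccccc34)=C2C#N)cc1` differs from compound 2 in one place: 4-methylphenyl in place of 2-methylphenyl on a saturated ring carbon. Among the measured compounds shown here, no measured pair shows what such a change does, so the size and direction of the step from compound 2 to compound 3 cannot be read from the numbers. Compound 3 is therefore expected to give 20%, with a range from 5% to 40%. This means an expected step of a number 1.4 percentage points lower from compound 2 to compound 3 (within the scatter), no larger than the scatter.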

Compound 3, a percentage reported as activity, at one concentration (the size of the read-out at that concentration, not a potency): 6.2%
For compound 3 the middle estimate is 13.8 percentage points above the measured one, within the range that was stated.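

In this assay, 4-methylphenyl in place of 2-methylphenyl gives a number 15.2 percentage points lower from compound 2 to compound 3 (beyond the scatter). The two groups have the same atoms and differ only in where the methyl sits on the phenyl ring, so this position on the saturated ring carbon responds to that placement alone. No available evidence bears on why the read-out shifts. Still open, on these data alone, is how 3-methylphenyl or plain phenyl would read out here, and whether a group such as an amine or a carboxylic acid on this phenyl ring would restore or further lower the effect.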